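The source may report more compounds than this note shows. Statements on the series, on what has been measured and on what is new or still open speak of the compounds shown alone.

Of the compounds shown here, three sharing one core have been tested in an ADME assay on BJ cells (Homo sapiens) for antiproliferative activity, with a stated time of 72 h; a higher number here means that more compound is needed for the effect, a lower number that less compound is needed. Compound 1 `COc1ccc(-c2cc(=O)c3c(OC)cc(OC)cc3n2C)cc1` gives 68000 nM. Compound 2 `COc1ccc(-c2cc(=O)c3c(OC)cc(OC)cc3n2Cc2ccccc2)cc1` reaches only a limit of the assay, > 34400 nM, so no number is known for it. Within the data shown here, compound 3 `COc1ccc(-c2c(Cl)c(=O)c3c(OC)cc(OC)cc3n2S(=O)(=O)c2ccc(OC)cc2)cc1` gives 90000 nM, the higher of the two numbers known; its nearest neighbour is compound 1, whose number lies within the scatter of it, so no order between the two can be stated. Among the measured compounds shown here, the only step between measured compounds that differ in a single place, a step that the limit leaves unreadable from compound 1 to compound 2, ends at a limit and its size cannot be read. That limit is the limit of > 34400 nM in this assay, at which 1 of the 3 values shown sits.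

Compound 4 `COc1ccc(-c2c(I)c(=O)c3c(OC)cc(OC)cc3n2S(=O)(=O)c2ccc(OC)cc2)cc1` has not yet been measured. It differs from compound 3 by iodo in place of chloro on an aromatic carbon. For the measured compounds named here, none of the measured steps exchanges one such atom for another, so no measured step bears directly on this change, and the one readable comparison, between compound 1 and compound 3, lies within the scatter. A step of no change at the digits printed from compound 3 to compound 4 (within the scatter) is therefore expected, none beyond the scatter. Compound 4 is expected to give about 90000 nM, with a range from 40000 nM to 200000 nM in this assay.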

Compound 4, half-maximal effective concentration: > 34400 nM
Compound 4: a limit, no number (the forecaster's own chance of this, stated with the estimate: 25%); the middle value does not contradict the limit.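

Among these compounds, the result for compound 4 is a limit of the assay, > 34400 nM, not a number, so no step from compound 3 to compound 4 can be read. The limit now recurs: the limit of > 34400 nM in this assay, at which 2 of the 4 values shown sit.

Going by these compounds, whether iodo in place of chloro on an aromatic carbon changes the concentration needed, and in which direction, stays open.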